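A few compounds are considered here, and "the series" means these few. Any claim that something is new, unique, unknown or untested is made for them only; others in the source may bear on it.

Of the two compounds measured in an ADME assay on cells (Hepatocyte, Rattus norvegicus, strain Wistar) for pharmacokinetics, read by LC-MS, with a stated time of 90 min, tested at 1 uM (a lower number here means slower removal, a higher number faster removal of the compound), compound 2 `COc1cc(C(=O)N2CCC(O)C(C)C2)cc2nc(NCc3cc(Cl)ccn3)oc12` stands lowest. Compound 1 `COc1cc(C(=O)N2CCC(O)C(C)C2)cc2nc(NCc3cccc(Cl)c3)oc12` gives 45 mL/min/kg, and compound 2 gives 14.3 mL/min/kg. The next structure, compound 3 `COc1cc(C(=O)N2CC(C)OCC2CCO)cc2nc(NCc3cc(Cl)ccn3)oc12`, keeps the 4-chloropyridin-2-yl group of compound 2 and changes the group on the carbonyl carbon: 5-(2-hydroxyethyl)-2-methylmorpholin-4-yl in place of 4-hydroxy-3-methylpiperidin-1-yl (5-(2-hydroxyethyl)-2-methylmorpholin-4-yl in place of 4-hydroxy-3-methylpiperidin-1-yl on a carbonyl carbon). Among the measured compounds shown here, the only measured step is a 3.1-fold lower number from compound 1 to compound 2 (0.50 log units; beyond the scatter), a modest one. It replaces 3-chlorophenyl with 4-chloropyridin-2-yl, a different place from the one changed now, so it bears on this change only indirectly. It does show that a single replacement can move this read-out beyond the scatter. For the measured compounds named here, no measured compound carries the new morpholine group, and the data give neither size nor direction for a change on the carbonyl carbon. No step beyond the scatter is therefore expected in this assay, but the range must stay wide on both sides. The expected change is a 1.1-fold higher number from compound 2 to compound 3 (0.05 log units; within the scatter). Compound 3 is expected to give about 16 mL/min/kg, with an estimated range of 7 mL/min/kg to 36 mL/min/kg.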

Compound 3, clearance: 20 mL/min/kg
Beside the measured number, compound 3's estimate is 1.3-fold (0.10 log units) below it; measured number inside the range.
By their numbers in this assay, from the lowest: compounds 2 and 3 (each within the scatter of the next); then compound 1.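

In this assay, the group on the carbonyl carbon now has its first measured step: with the 4-chloropyridin-2-yl group held constant, putting 5-(2-hydroxyethyl)-2-methylmorpholin-4-yl in place of 4-hydroxy-3-methylpiperidin-1-yl gives a 1.4-fold higher number from compound 2 to compound 3 (0.15 log units; within the scatter), and the two compounds cannot be told apart in this read-out. The position therefore accepts a group of 10 heavy atoms in place of 8, with 2 hydrogen-bond acceptors in place of 1, without a step beyond the scatter, at least for this one replacement in the presence of the 4-chloropyridin-2-yl group. Nothing at hand gives a reason for this result.

The exchange alters the ring hetero atoms, the chain carrying the hydroxyl and the place of the methyl together, so the compounds shown cannot separate what each of these contributes to the step. They also leave open whether the same replacement would hold alongside the 3-chlorophenyl group of compound 1, and how a piperazine ring or a carboxylic acid in place of the hydroxyl would read on this carbonyl carbon.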